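Pyridazin-3-yl swap at the sulfonamide nitrogen

This account rests on a few compounds, and the source may have more. Where it says the series, first, only, none or still open, it means among the compounds named here.

In a physicochemical assay for solubility (on this read-out higher numbers stand for higher solubility and lower numbers for lower solubility), compound 1 (`O=S(=O)(Nc1ncccn1)c1ccc2c(c1)OCC[C@@H]2c1ccc(C(F)(F)F)cc1-c1ccc(F)nc1`) gives 408000 nM and compound 3 (`Cn1nccc1-c1cc(C(F)(F)F)ccc1[C@H]1CCOc2cc(S(=O)(=O)Nc3ncccn3)ccc21`) gives 532000 nM, level within the scatter. Compound 2 (`O=S(=O)(Nc1ncccn1)c1ccc2c(c1)CC[C@@H]2c1ccc(C(F)(F)F)cc1-c1ccc(F)nc1`) gives 40000 nM, a number that both of the others clearly exceed. Compound 4 (`Cn1nccc1-c1cc(C(F)(F)F)ccc1[C@H]1CCOc2cc(S(=O)(=O)Nc3cccnn3)ccc21`) differs from compound 3 by pyridazin-3-yl in place of pyrimidin-2-yl on a sulfonamide nitrogen. Within the data shown here, no measured step touches this place. Among the measured compounds shown here, the one measured step, a 1.3-fold higher number from compound 1 to compound 3 (0.12 log units; within the scatter), sits on an aromatic carbon and bears only indirectly. The expectation therefore starts from compound 3 at 532000 nM, with no change beyond the scatter foreseen. The expected step is a 1.3-fold lower number from compound 3 to compound 4 (0.12 log units; within the scatter). For compound 4 the estimated value is 400000 nM, with an expected range of 130000 nM to 900000 nM.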

Compound 4, solubility: 915000 nM
The estimate for compound 4 lay 2.3-fold (0.36 log units) below the measured number; the whole stated range lies below it.
By their numbers in this assay, from the lowest: compound 2; then compounds 1, 3 and 4 (each within the scatter of the next, the first and the last beyond it).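

In this assay, among these compounds, the only measured change on the sulfonamide nitrogen, pyridazin-3-yl in place of pyrimidin-2-yl, leaves the read-out level (a 1.7-fold higher number from compound 3 to compound 4 (0.24 log units; within the scatter)). This position therefore accepts either group on the shared core of compound 3 without a step beyond the scatter. No measured property bears on this result.

Open, on these data alone, is whether the position stays level with a different kind of group on the sulfonamide nitrogen, such as thiazol-2-yl or a plain methyl. Also open, as far as these compounds go, is whether the same swap holds alongside the 6-fluoropyridin-3-yl group of compound 1.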